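This account rests on a few compounds, and the source may have more. Where it says the series, first, only, none or still open, it means among the compounds named here.

Measured so far:
- compound 1, `COC1=CC(c2ccco2)=N/C1=C\c1ccc[nH]1`: > 40000 nM
- compound 2, `COc1cc(-c2cc3ccccc3[nH]2)[nH]c1/C=C1/SC(=O)NC1=O`: 27500 nM
- compound 3, `COC1=CC(c2cc3cc(Br)ccc3[nH]2)=N/C1=C\c1ccc[nH]1`: 6300 nM

All three were tested in a functional assay on PLC5 cells (Homo sapiens) for cytotoxicity, read by MTT assay; on this read-out lower numbers stand for stronger inhibition and higher numbers for weaker inhibition. For compound 1 the value > 40000 nM is a limit of the assay, not a number; it sits at the limit of > 40000 nM in this assay, at which 1 of the 3 values shown sits. Compound 2 gives 27500 nM in this assay. Compound 3 gives 6300 nM, the lowest of the two numbers reported, and the gap to compound 2 is beyond the usual scatter of this kind of measurement.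

Compound 4, `COC1=CC(c2cc3ccccc3[nH]2)=N/C1=C\c1ccc[nH]1`, has not yet been measured in this assay. It differs from compound 3 in one place: hydrogen in place of bromo on an aromatic carbon. Among the measured compounds shown here, no two compounds measured so far differ in exactly one place, so there is no directly comparable step to lean on. The bromine is a single heavy atom, and its removal is a small change by count; still, since compound 3 is the lowest number among the compounds shown and compound 2 without that bromine sits higher, the expectation is a modest rise in the number, possibly within the scatter, as the step of a 1.9-fold higher number from compound 3 to compound 4 (0.28 log units; within the scatter) expresses. Compound 4 is therefore estimated at 12000 nM, with a plausible range from 4000 nM to 40000 nM.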

Compound 4, half-maximal inhibitory concentration: 13200 nM
For compound 4 the middle estimate is 1.1-fold (0.04 log units) below the measured one, within the range that was stated.
By their numbers in this assay, from the lowest: compound 3; then compound 4; then compound 2. At a limit, above all of these: compound 1.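

Among the compounds shown here, the step between these two compounds is the first direct comparison in this set. They differ in one place only: bromo gives way to hydrogen on an aromatic carbon of the six-membered aromatic ring, and this assay records a 2.1-fold higher number from compound 3 to compound 4 (0.32 log units; beyond the scatter). This is a modest step, but it lies beyond the usual scatter, so the loss of a single heavy atom at this position does register in the read-out. The bromine is not needed for a measured number, however, as compound 4 without it still gives 13200 nM and the difference from compound 3 stays small. Nothing measured here explains why the number rises when the bromine leaves.

The compounds shown hold only bromo and hydrogen at this carbon, so it remains open whether another halogen such as chloro, a small chain such as methyl, or a group such as an amine or a carboxylic acid would give a lower or a higher number. Going by these compounds, it also remains open whether the same change would have a similar effect at the other carbons of that ring, or on a different core.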